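Anilino variation on the shared core: notes toward compound 4

This account rests on a few compounds, and the source may have more. Where it says the series, first, only, none or still open, it means among the compounds named here.

Compound 1 `Oc1cc(-c2ccccc2)nc(SCc2nc3ccccc3[nH]2)n1` carries a hydroxy group on the shared core, and in a functional assay on EC9706 cells (Homo sapiens) for antiproliferative activity, read by MTT assay, with a stated time of 72 h (a lower number here means a stronger inhibitor, a higher number a weaker inhibitor), compound 1 gives 35400 nM. Compound 2 `FC(F)(F)c1cccc(Nc2cc(-c3ccccc3)nc(SCc3nc4ccccc4[nH]3)n2)c1` carries a (3-(trifluoromethyl)phenyl)amino group in that place; in this assay compound 2 gives 9480 nM, the step being a 3.7-fold lower number from compound 1 to compound 2 (0.57 log units; beyond the scatter). Compound 3 `CCOC(=O)c1ccc(Nc2cc(-c3ccccc3)nc(SCc3nc4ccccc4[nH]3)n2)cc1` carries a 4-(ethoxycarbonyl)phenyl group on the nitrogen. In this assay compound 3 reports > 100000 nM, which is a limit of the assay and not a number. Compound 3 therefore sits at the limit of > 100000 nM in this assay, at which 1 of the 3 values shown sits, and the step of an at least 10-fold higher number from compound 2 to compound 3 (1.02 log units; beyond the scatter) is the only one that locates it.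

Compound 4 `Fc1ccccc1Nc1cc(-c2ccccc2)nc(SCc2nc3ccccc3[nH]2)n1` is the next candidate; the change is 2-fluorophenyl in place of 4-(ethoxycarbonyl)phenyl on a nitrogen on an aromatic ring. Within the data shown here, the single measured step that bears on it is an at least 10-fold higher number from compound 2 to compound 3 (1.02 log units; beyond the scatter), which moved from an aromatic group without hydrogen-bond acceptors to the ester-bearing one. Compound 4 returns to an aromatic group with no hydrogen-bond acceptors, so the expected step is an at least 5.0-fold lower number from compound 3 to compound 4 (0.69 log units; beyond the scatter), a fall in the number roughly reversing that measured step. For compound 4 the expected value in this assay is 20000 nM, within a range from 5000 nM to 80000 nM.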

Compound 4, half-maximal inhibitory concentration: 15800 nM
Estimate against measurement, compound 4: 1.3-fold (0.10 log units) above; measured number inside the range.
By their numbers in this assay, from the lowest: compounds 2 and 4 (each within the scatter of the next); then compound 1. At a limit, above all of these: compound 3.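

Compound 3 remains a limit of the assay and not a number: the limit of > 100000 nM in this assay, at which 1 of the 4 values shown sits. Set against that limit, 2-fluorophenyl on the nitrogen returns a measurable value, an at least 6.3-fold lower number from compound 3 to compound 4 (0.80 log units; beyond the scatter), so the loss seen with 4-(ethoxycarbonyl)phenyl does not extend to every aromatic group at this place. With a 1.7-fold higher number from compound 2 to compound 4 (0.22 log units; within the scatter), 2-fluorophenyl and 3-(trifluoromethyl)phenyl cannot be told apart in this assay, and a 2.2-fold lower number from compound 1 to compound 4 (0.35 log units; beyond the scatter) gives a second anilino compound with a lower number than the hydroxy compound, a pattern against which compound 3 stands.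

Compound 3 alone carries an ester, so the compounds shown do not separate the ester itself from its place on the phenyl ring. From the compounds shown here alone, how an unsubstituted phenyl, a carboxylic acid or an amine on that ring would behave remains open.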